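Dropping the second chloro from the dichloropurine core

The source may hold more compounds than are shown below. What is called first, only, known or untested is meant among the compounds shown, and "the series" means these compounds.

Compound 1 `ClCc1cccc(Cn2cnc3c(Cl)nc(Cl)nc32)c1` is examined in a functional assay on LOX IMVI cells (Homo sapiens) for cytotoxicity, read by sulforhodamine B assay, with a stated time of 48 h; a lower number here means that less compound is tolerated, a higher number that more compound is tolerated. Among the two numbers in hand it stands lowest: compound 1 gives 6910 nM, and its nearest neighbour, compound 3 `ClCc1cccc(Cn2cnc3ncnc(Cl)c32)c1`, gives 43700 nM, a gap beyond the usual scatter. Compound 2 `Nc1nc(Cl)c2ncn(Cc3ccc(CCl)cc3)c2n1` is reported in this assay only as a limit, > 100000 nM (the limit of > 100000 nM in this assay, at which 1 of the 3 values shown sits).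

The step to compound 4 `ClCc1cccc(Cn2cnc3c(Cl)ncnc32)c1` is a single change on the core of compound 1: hydrogen in place of chloro on an aromatic carbon. Among the measured compounds shown here, no two measured compounds differ in just this one place, so no measured step tells its size directly. For the measured compounds named here, what the set does show is that compound 3, which also carries only one chloro on its core, sits well above compound 1 in this assay, and that compound 2, with an amino group on its core instead, reaches only the limit. On that basis the step from compound 1 to compound 4 is expected to move the number upward, by an amount beyond the scatter, so that in this assay compound 4 is estimated at 20000 nM, with a likely range from 7000 nM to 60000 nM, corresponding to a step of a 2.9-fold higher number from compound 1 to compound 4 (0.46 log units; beyond the scatter).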

Compound 4, concentration lethal to 50% of the cells: 27500 nM
For compound 4 the middle estimate is 1.4-fold (0.14 log units) below the measured one, within the range that was stated.
By their numbers in this assay, from the lowest: compound 1; then compounds 4 and 3 (each within the scatter of the next). At a limit, above all of these: compound 2.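

In this assay, the chloro on the aromatic carbon between two ring nitrogen atoms now has a step of its own: replacing it with hydrogen gives a 4.0-fold higher number from compound 1 to compound 4 (0.60 log units; beyond the scatter), with the rest of compound 1 unchanged. The earlier compounds shown here could only hint at this, since none of them differed from compound 1 in this one place, whereas this pair shows directly that the low number of compound 1 depends on the chloro at this position and is not carried by the other chloro on the core alone. Once this chloro is gone, compound 4 gives 27500 nM and compound 3 gives 43700 nM, two values within the scatter of each other.

The compounds shown leave open what an amine, a methoxy group or a fluoro at this position would do to the number, and what removing the other chloro on its own would do. Nothing at hand bears on why the number moves with this change.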